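The compounds below may be only part of what the source reports. "The series", "measured", "known", "first", "only" and "open" are said of these compounds alone.

Measured compounds:

Compound 1, `O=C(/C=C\c1ccccc1O)N1N=C(c2ccncc2)OC1c1c[nH]c2ccccc12`. In an ADME assay on PANC-1 cells (Homo sapiens) for cytotoxicity, read by MTT assay, with a stated time of 48 h (on this read-out lower numbers stand for stronger inhibition of growth and higher numbers for weaker inhibition of growth), compound 1 gives > 30 ug/mL, which is a limit of the assay and not a number.

Compound 2, `O=C(/C=C\c1ccc(O)cc1)N1N=C(c2ccncc2)OC1c1c[nH]c2ccccc12`. In this assay compound 2 gives > 30 ug/mL, again a limit of the assay rather than a number.

Among the compounds with values here, compound 2 therefore stands only at a limit in this assay; the one other value shown, that of compound 1, is a limit too, so both sit at the limit of > 30 ug/mL in this assay, at which 2 of the 2 values shown sit. The step that the two limits leave unreadable from compound 1 to compound 2 cannot be read, since neither end is a number.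

Compound 3, `O=C(/C=C\c1ccc([N+](=O)[O-])cc1)N1N=C(c2ccncc2)OC1c1c[nH]c2ccccc12`, is the next one to be measured in this assay. It differs from compound 2 in one place: nitro in place of hydroxy on an aromatic carbon. No measured step bears on this change, as the only step shown, from compound 1 to compound 2, has no readable size. Nothing here points in either direction. The estimate for compound 3 is therefore 30 ug/mL, within a range from 8 ug/mL to 120 ug/mL, which means an expected step of a number no higher from compound 2 to compound 3 (the limit leaves the size open) from compound 2 to compound 3, with a good chance that only a limit is reported again.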

Compound 3, concentration for 50% growth inhibition: > 30 ug/mL
Compound 3 was reported as a limit (the forecaster's own chance of this, stated with the estimate: 55%); the middle value lies on the limit itself.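

In this assay compound 3 gives > 30 ug/mL, which is a limit of the assay and not a number. Within the data shown here, no step among compound 1, compound 2 and compound 3 can therefore be read, since all three stand at one limit: the limit of > 30 ug/mL in this assay, at which 3 of the 3 values shown sit. The compounds shown leave open how strongly each inhibits growth, and whether swapping hydroxy for nitro changes that at all.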